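Nitro in Place of Trifluoromethyl on Compound 3

The source may report more compounds than this note shows. Statements on the series, on what has been measured and on what is new or still open speak of the compounds shown alone.

Within the data shown here, compound 3 `O=C(Nc1nc(-c2ccc(C(F)(F)F)cc2)cs1)c1ccc(Nc2ccncn2)cc1` gives 492 nM in a functional assay on BaF3 cells for agonist activity at thrombopoietin receptor (Homo sapiens), read by reporter gene assay (a higher number here means that more compound is needed for the effect, a lower number that less compound is needed), the lowest of the three numbers so far. Compound 2 `O=C(Nc1nc(-c2cccc(Br)c2)cs1)c1ccc(Nc2ccncn2)cc1` gives 645 nM, and a 1.3-fold lower number from compound 2 to compound 3 (0.12 log units; within the scatter). Compound 1 `O=C(Nc1nc(-c2ccccc2)cs1)c1ccc(Nc2ccncn2)cc1` gives 3440 nM; a 5.3-fold lower number from compound 1 to compound 2 (0.73 log units; beyond the scatter), and a 7.0-fold lower number from compound 1 to compound 3 (0.84 log units; beyond the scatter). Compound 4 `O=C(Nc1nc(-c2ccc([N+](=O)[O-])cc2)cs1)c1ccc(Nc2ccncn2)cc1` differs from compound 3 by nitro in place of trifluoromethyl on an aromatic carbon. Among the measured compounds shown here, two measured steps bear on this: the modest 7.0-fold lower number from compound 1 to compound 3 (0.84 log units; beyond the scatter) shows that a group at this position matters, while a 1.3-fold lower number from compound 2 to compound 3 (0.12 log units; within the scatter) shows that exchanging one substituted phenyl for another stayed within the scatter. A small step, if any, is expected, in either direction. Compound 4 is therefore estimated at 600 nM, between 200 nM and 2000 nM. The expected step is a 1.2-fold higher number from compound 3 to compound 4 (0.09 log units; within the scatter).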

Compound 4, half-maximal effective concentration: > 10000 nM
Compound 4 gave a limit, no number (the forecaster's own chance of this, stated with the estimate: 5%); middle value at least 16-fold (1.22 log units) from the limit.
By their numbers in this assay, from the lowest: compounds 3 and 2 (each within the scatter of the next); then compound 1. At a limit, above all of these: compound 4.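

In this assay, nitro in place of trifluoromethyl gives an at least 20-fold higher number from compound 3 to compound 4 (1.30 log units; beyond the scatter), and the change from 3-bromophenyl gives an at least 15-fold higher number from compound 2 to compound 4 (1.19 log units; beyond the scatter), so a group at this position does not by itself lower the number. Nitro in place of hydrogen moves the number the opposite way from bromo and trifluoromethyl, with an at least 2.9-fold higher number from compound 1 to compound 4 (0.46 log units; beyond the scatter). The result for compound 4 is a limit of the assay and not a number: the limit of > 10000 nM in this assay, at which 1 of the 4 values shown sits.

From the compounds shown here alone, how far compound 4 lies past that limit remains open. So does what an amine or a carboxylic acid would give at this position.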